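This account rests on a few compounds, and the source may have more. Where it says the series, first, only, none or still open, it means among the compounds named here.

Measured compounds:
Compound 1, `COc1cc(-c2nc(SCc3cn(CC(=O)NC(=O)Nc4ccccn4)nn3)nc(Nc3ccc(C)cc3)c2C#N)cc(OC)c1OC`: 21300 nM
Compound 2, `COc1cc(-c2nc(SCc3cn(CC(=O)NC(=O)Nc4ccccn4)nn3)nc(Nc3cccc(Cl)c3)c2C#N)cc(OC)c1OC`: > 64000 nM

For the measured compounds named here, in a functional assay on ECa-109 cells (Homo sapiens) for inhibition, read by MTT assay, with a stated time of 72 h (on this read-out higher numbers stand for weaker inhibition and lower numbers for stronger inhibition), compound 1 gives 21300 nM, the only full number among the two. For compound 2 the assay reports only a limit, > 64000 nM (the limit of > 64000 nM in this assay, at which 1 of the 2 values shown sits). Going by the values given here, the single measured step is an at least 3.0-fold higher number from compound 1 to compound 2 (0.47 log units; beyond the scatter). Compound 3, `Cc1ccc(Nc2nc(SCc3cn(CC(=O)NC(=O)Nc4ccccn4)nn3)nc(-c3ccc(Br)cc3)c2C#N)cc1`, differs from compound 1 by 4-bromophenyl in place of 3,4,5-trimethoxyphenyl on an aromatic carbon. Among the compounds with values here, no measured step touches this group; the measured step alters the (4-methylphenyl)amino group instead, so it offers no direct guidance. Compound 3 is expected to give 45000 nM (range 12000 nM to 150000 nM), an estimated step of a 2.1-fold higher number from compound 1 to compound 3 (0.32 log units; beyond the scatter) toward weaker inhibition, with a fair chance that only a limit is reported.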

Compound 3, half-maximal inhibitory concentration: 7920 nM
Compound 3: middle estimate off by 5.7-fold (0.75 log units), on the high side; measured number outside the range, below it.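

In this assay, 4-bromophenyl in place of 3,4,5-trimethoxyphenyl gives a 2.7-fold lower number from compound 1 to compound 3 (0.43 log units; beyond the scatter), a move toward stronger inhibition. This position, untouched by the earlier step, therefore responds to change, and the methoxy groups of compound 1 are not required for activity here. Nothing available accounts for this step.

Still open, as far as these compounds go, is whether the bromine or the loss of the methoxy groups carries the step, which a plain phenyl or a 4-methoxyphenyl group here would help separate. Also open, from the compounds shown here alone, is whether 3-chlorophenyl on the nitrogen would weaken inhibition alongside 4-bromophenyl.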